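Rejoining the pyrazole of compound 2

The compounds below may be only part of what the source reports. "The series", "measured", "known", "first", "only" and "open" are said of these compounds alone.

Compound 1 `Cn1nccc1-c1cnc(NCc2c(F)ccc3c2CCO3)c2cn[nH]c(=O)c12`: 14 mL.min-1.g-1
Compound 2 `Cc1cc(-c2cnc(NCc3c(F)ccc4c3CCO4)c3cn[nH]c(=O)c23)n(C)n1`: 24 mL.min-1.g-1

These values come from an ADME assay on microsomes from liver (Homo sapiens) for metabolic stability, read by LC-MS, using NADPH, with stated times of 5 min and 30 min, tested at 1 uM; on this read-out higher numbers stand for fast clearance and lower numbers for slow clearance. Compound 2, at 24 mL.min-1.g-1, stands within the scatter of compound 1. Compound 3 `Cc1nn(C)cc1-c1cnc(NCc2c(F)ccc3c2CCO3)c2cn[nH]c(=O)c12` has the same atoms as compound 2, joined differently: 1,3-dimethyl-1H-pyrazol-4-yl in place of 1,3-dimethyl-1H-pyrazol-5-yl on an aromatic carbon. Here 1,3-dimethyl-1H-pyrazol-4-yl takes the place of 1,3-dimethyl-1H-pyrazol-5-yl on an aromatic carbon. Going by the values given here, only one measured step offers guidance, a 1.7-fold higher number from compound 1 to compound 2 (0.23 log units; within the scatter), and it swaps hydrogen for methyl rather than rejoining the ring. The step expected in this assay is therefore small, a 1.2-fold lower number from compound 2 to compound 3 (0.08 log units; within the scatter), with nothing expected beyond the scatter. Compound 3 is estimated at 20 mL.min-1.g-1, within a range of 9 mL.min-1.g-1 to 45 mL.min-1.g-1.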

Compound 3, intrinsic clearance in microsomes: 27 mL.min-1.g-1
The estimate for compound 3 lay 1.4-fold (0.13 log units) below the measured number; the measured number falls inside the stated range.
By their numbers in this assay, from the lowest: compounds 1, 2 and 3 (each within the scatter of the next).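

Moving the attachment point of the dimethylpyrazole on the shared core leaves this assay within the scatter (a 1.1-fold higher number from compound 2 to compound 3 (0.05 log units; within the scatter)). Compared with the ring lacking the extra methyl, 1,3-dimethyl-1H-pyrazol-4-yl also stays within the scatter (a 1.9-fold higher number from compound 1 to compound 3 (0.29 log units; within the scatter)), so neither the 5-yl nor the 4-yl attachment stands apart from compound 1 on this read-out. Nothing available explains why these numbers lie so close.
Still open, on these data alone, is how clearance responds to a different kind of group at this position, such as an amine or a carboxylic acid. Also open, as far as these compounds go, is what 1-methyl-1H-pyrazol-4-yl, the rejoined ring without its carbon-bound methyl, would give.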